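Fluoro for Hydrogen on the Phenyl Ring of Compound 1

A few compounds are considered here, and "the series" means these few. Any claim that something is new, unique, unknown or untested is made for them only; others in the source may bear on it.

Compound 1 `COc1nc(-c2cc3ccccc3o2)cc(-c2ccccc2)c1C#N` and compound 2 `CCOc1nc(-c2cc3ccccc3o2)cc(-c2ccccc2)c1C#N` share one core and differ only in the group bound to the oxygen on the aromatic ring. In a functional assay on aorta (strain Wistar) for inhibition, with Thoracic aorta (Rattus norvegicus) as the target (on this read-out lower numbers stand for stronger inhibition and higher numbers for weaker inhibition), compound 1 gives 232000 nM, and compound 2 gives 310000 nM. Compound 1 thus has the lower of the two numbers, but the gap, a 1.3-fold higher number from compound 1 to compound 2 (0.13 log units; within the scatter), lies within the scatter of repeated measurements, so neither compound can be set above the other.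

Compound 3 `COc1nc(-c2cc3ccccc3o2)cc(-c2ccc(F)cc2)c1C#N` is compound 1 with a single change: fluoro in place of hydrogen on an aromatic carbon. Among the measured compounds shown here, no measured step touches this ring. For the measured compounds named here, the one step at hand, a 1.3-fold higher number from compound 1 to compound 2 (0.13 log units; within the scatter), concerns the chain on the oxygen and is itself within the scatter, so it gives no ground to expect a shift in either direction from the new fluoro group. The expected outcome in this assay is no change at the digits printed from compound 1 to compound 3 (within the scatter), which is to say nothing beyond the scatter. Compound 3 is accordingly estimated to give 232000 nM in this assay, with a range from 110000 nM to 480000 nM.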

Compound 3, half-maximal inhibitory concentration: 321000 nM
Compound 3: the middle estimate sits 1.4-fold (0.14 log units) below what was measured, within the range that was stated.
By their numbers in this assay, from the lowest: compounds 1, 2 and 3 (each within the scatter of the next).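

The phenyl ring of the shared core now has its first reading: in this assay, the change from phenyl to 4-fluorophenyl gives a 1.4-fold higher number from compound 1 to compound 3 (0.14 log units; within the scatter) for fluoro in place of hydrogen on an aromatic carbon, para to a large group. The earlier pair differed only in the group on the oxygen, so this is a second place on the core where a single small change stays within the scatter, and no order can be set among the three compounds on this read-out. Nothing at hand bears on why a fluoro group at this place gives this result.

The compounds shown leave open whether a different group at this place, such as chloro, an amine or a carboxylic acid, or fluoro on another carbon of this ring, would carry the number beyond the scatter. Also open, going by these compounds, is whether a longer chain on the oxygen, such as propyl or butyl, or a carboxylic acid in place of the nitrile, would separate compounds that so far cannot be told apart.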